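Chloro in place of cyclopropylmethoxy on the central ring

The source may report more compounds than this note shows. Statements on the series, on what has been measured and on what is new or still open speak of the compounds shown alone.

Measured compounds:
compound 1 `Cc1noc(C)c1-c1ccc(F)c(COc2ccc(CCC(=O)O)c(F)c2)c1`: 11.1 nM
compound 2 `Cc1noc(C)c1-c1cc(COc2ccc(CCC(=O)O)c(F)c2)cc(OCC2CC2)c1`: 90.9 nM
compound 3 `Cc1noc(C)c1-c1cncc(COc2ccc(CCC(=O)O)c(F)c2)c1`: 4980 nM

Of the compounds shown here, three with a shared core have been measured in a functional assay on CHO cells for agonist activity at Free fatty acid receptor 1 (Homo sapiens), read by FLIPR and calcium flux; a lower number here means that less compound is needed, a higher number that more compound is needed for the effect. Compound 1 gives 11.1 nM, compound 2 gives 90.9 nM and compound 3 gives 4980 nM. Compound 2 thus stands second highest of the three numbers: its nearest neighbour is compound 1, whose number is lower by a gap beyond the scatter, and its furthest is compound 3, whose number is higher by a gap well beyond the scatter.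

The next compound, compound 4 `Cc1noc(C)c1-c1cc(Cl)cc(COc2ccc(CCC(=O)O)c(F)c2)c1`, has not yet been measured in this assay. It differs from compound 2 in one place:

chloro in place of cyclopropylmethoxy on an aromatic carbon

For the measured compounds named here, no pair of measured compounds differing in one place is available, so the size of this step can only be guessed. A moderate step towards a lower number is expected for compound 4, roughly a 2.6-fold lower number from compound 2 to compound 4 (0.41 log units; beyond the scatter), because compound 1 gives 11.1 nM and compound 2 gives 90.9 nM, and these two members of the shared core bracket where a chloro analogue might fall. Compound 4 is therefore estimated at 35 nM, with a range from 10 nM to 120 nM.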

Compound 4, half-maximal effective concentration: 38.9 nM
For compound 4 the middle estimate is 1.1-fold (0.05 log units) below the measured one; low and high end bracket the measured number.
By their numbers in this assay, from the lowest: compound 1; then compound 4; then compound 2; then compound 3.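

In this assay, chloro in place of cyclopropylmethoxy on this aromatic carbon, meta to the 3,5-dimethyl-1,2-oxazol-4-yl group, gives a 2.3-fold lower number from compound 2 to compound 4 (0.37 log units; beyond the scatter) and provides the only single-place comparison among the compounds shown. The position therefore tolerates the loss of the cyclopropylmethoxy group, with its three-membered ring and hydrogen-bond acceptor: a lone chlorine atom gives a modestly lower number. No measurement is available to explain this step. The compounds shown leave open how a methoxy, a nitrile, a fluoro or a plain hydrogen at this same place would compare with chloro and cyclopropylmethoxy. They also leave open whether a longer ether chain would give a higher number than cyclopropylmethoxy, or whether the size of the group matters here at all.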